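The compounds below may be only part of what the source reports. "The series", "measured", "known", "first", "only" and "open" are said of these compounds alone.

Measured in a functional assay on MCF7 cells (Homo sapiens) for antiproliferative activity, read by sulforhodamine B assay, with a stated time of 72 h; on this read-out lower numbers stand for stronger inhibition and higher numbers for weaker inhibition:
- compound 1 `Cc1ccc(S(=O)(=O)Nc2cc(SCC(=O)N[C@@H](CC(C)C)B(O)O)c(O)c3ccccc23)cc1`: 12800 nM
- compound 2 `CC(C)C[C@H](NC(=O)CSc1cc(NS(=O)(=O)c2ccccc2)c2ccccc2c1O)B(O)O`: 4160 nM
- compound 3 `CC(C)C[C@H](NC(=O)CSc1cc(NS(=O)(=O)c2ccc(Cl)cc2)c2ccccc2c1O)B(O)O`: 10400 nM

Compound 3 stands in the upper part of this small set. The gap to its nearest neighbour is a 1.2-fold lower number from compound 1 to compound 3 (0.09 log units; within the scatter), and the gap to its furthest is a 2.5-fold higher number from compound 2 to compound 3 (0.40 log units; beyond the scatter).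

The next compound is compound 4 `CC(C)C[C@H](NC(=O)CSc1cc(NS(=O)(=O)c2cccs2)c2ccccc2c1O)B(O)O`. The change is thiophen-2-yl in place of 4-chlorophenyl on a sulfonyl sulfur. Going by the values given here, no measured step replaces the aromatic ring itself, so there is no direct precedent and any expectation rests on indirect evidence. The closest evidence is the chloro step, a 2.5-fold higher number from compound 2 to compound 3 (0.40 log units; beyond the scatter), read in reverse, since compound 4 also carries no chloro. The methyl step, a 3.1-fold lower number from compound 1 to compound 2 (0.49 log units; beyond the scatter), runs the same way, while the exchange of chloro for methyl, a 1.2-fold lower number from compound 1 to compound 3 (0.09 log units; within the scatter), shows no separation. In this set, only the compound without a group in place of that chloro or methyl gives the lower number, and three compounds are thin support. The expected change is therefore modest and toward a lower number, with a ring exchange adding uncertainty in both directions. The step expected is a 1.9-fold lower number from compound 3 to compound 4 (0.28 log units; within the scatter). For compound 4 the estimated value in this assay is 5500 nM, with an expected range of 2200 nM to 12000 nM.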

Compound 4, half-maximal inhibitory concentration: 9450 nM
The estimate for compound 4 lay 1.7-fold (0.24 log units) below the measured number, and the stated range covers the measured number.
By their numbers in this assay, from the lowest: compound 2; then compounds 4, 3 and 1 (each within the scatter of the next).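

In this assay, the aromatic group on the sulfonyl sulfur is now exchanged directly: thiophen-2-yl in place of 4-chlorophenyl gives a 1.1-fold lower number from compound 3 to compound 4 (0.04 log units; within the scatter) and thiophen-2-yl in place of 4-methylphenyl gives a 1.4-fold lower number from compound 1 to compound 4 (0.13 log units; within the scatter) and so neither exchange separates the two compounds involved. Only the phenyl compound stands apart, with a 2.3-fold higher number from compound 2 to compound 4 (0.36 log units; beyond the scatter) and this makes compound 4 an exception to the earlier pattern in which the compound lacking a chloro or methyl group gave the lower number, so among the four compounds the lower number belongs to compound 2 alone, and compounds 1, 3 and 4 are not separated from one another by the steps shown. Nothing measured here accounts for the separation of compound 2 from the other three.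

Still open, from the compounds shown here alone, is whether the separation of compound 2 belongs to phenyl specifically or would extend to other unsubstituted aromatic rings such as furan-2-yl or pyridin-3-yl. Also open, going by these compounds, is how the number would respond to a methoxy group, an amine or a carboxylic acid on the phenyl ring, or to a simple methyl or longer alkyl chain on the sulfonyl sulfur in place of any ring.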